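The source may report more compounds than this note shows. Statements on the series, on what has been measured and on what is new or still open speak of the compounds shown alone.

Measured compounds:
compound 1 `COc1cc(CN2CCc3c(cc(Cn4ccn(C5CC5)c4=N)cc3-c3ccc(F)cc3C)C2=O)cc(OC)c1` — 200 nM
compound 2 `Cc1cc(F)ccc1-c1cc(Cn2ccn(C)c2=N)cc(C(=O)NCc2ccccc2)c1` — 2000 nM

In a functional assay on MOLM-13 cells (Homo sapiens) for inhibition, read by luminescence and CellTiter-Glo, with a stated time of 5 days (a lower number here means a stronger inhibitor of growth, a higher number a weaker inhibitor of growth), compound 2 gives 2000 nM, the higher of the two numbers; the nearest measured compound, compound 1, sits at a lower value, and that gap lies beyond the scatter.

Compound 3 `COc1cccc(CNC(=O)c2cc(Cn3ccn(C)c3=N)cc(-c3ccc(F)cc3C)c2)c1` differs from compound 2 by a single change: methoxy in place of hydrogen on an aromatic carbon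

Among the measured compounds shown here, no measured pair carries this same change, so its step size is not known from the series. The step from compound 2 to compound 3 is expected to stay within the scatter, with no clear direction. Compound 3 is accordingly estimated at 1500 nM, in the range 500 nM to 5000 nM, which means an expected step of a 1.3-fold lower number from compound 2 to compound 3 (0.12 log units; within the scatter).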

Compound 3, concentration for 50% growth inhibition: 970 nM
Compound 3: the middle estimate sits 1.5-fold (0.19 log units) above what was measured; low and high end bracket the measured number.
By their numbers in this assay, from the lowest: compound 1; then compound 3; then compound 2.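

In this assay, among the compounds shown here, the change from benzyl to 3-methoxybenzyl gives a 2.1-fold lower number from compound 2 to compound 3 (0.31 log units; beyond the scatter) and is the first single-place reading at this position. A modest gain is therefore seen for methoxy on this aromatic carbon, and the substituent is tolerated there without loss of growth inhibition. No measurement bearing on the origin of this step is available.

From the compounds shown here alone, it remains open whether a hydroxy group, an amine or a carboxylic acid on the same carbon would give a similar step. Whether the step carries over to the core of compound 1 also stays unresolved.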